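The source may hold more compounds than are shown below. What is called first, only, known or untested is meant among the compounds shown, and "the series" means these compounds.

Among the measured compounds shown here, in a physicochemical assay for solubility, read by HPLC, in phosphate buffer, measured as kinetic solubility, with a stated time of 24 h, at pH 7.4, tested at 200 uM (on this read-out lower numbers stand for lower solubility and higher numbers for higher solubility), compound 1 `CCc1cccc(CC)c1N1CCn2cc(-c3nc(Nc4ccc(N5CCC(C(=O)N6CCN(C)CC6)CC5)cc4OC)nc4[nH]ccc34)cc2C1=O` gives 800 nM and compound 2 `CCc1cccc(CC)c1N1CCn2cc(-c3nc(Nc4ccc(N5CCC(C(=O)N(C)CCN(C)C)CC5)cc4OC)nc4[nH]ccc34)cc2C1=O` gives 125000 nM, so compound 2 holds the higher of the only two numbers available. Compound 3 `CCc1cccc(CC)c1N1CCn2cc(-c3nc(Nc4ccc(N5CCC(C(=O)N6CC7(CN(C)C7)C6)CC5)cc4OC)nc4[nH]ccc34)cc2C1=O` keeps the shared core and changes the group on the same carbonyl carbon: a group of 8 heavy atoms (6 carbon, 2 nitrogen; 2 four-membered non-aromatic rings with 1 hetero atom each) in place of a group of 7 heavy atoms (5 carbon, 2 nitrogen; no ring), on a carbonyl carbon. For the measured compounds named here, one measured step bears on this place: a 160-fold higher number from compound 1 to compound 2 (2.19 log units; beyond the scatter), a large step beyond the scatter, with (2-(dimethylamino)ethyl)(methyl)amino in place of 4-methylpiperazin-1-yl. The incoming group in compound 3 resembles 4-methylpiperazin-1-yl in having rings, while the group it replaces has none, but it is a different group, and a single pair cannot show how far that resemblance carries. In this assay, a lower number is therefore expected, though a smaller drop than the size of the measured step would suggest. The estimated change is a 3.1-fold lower number from compound 2 to compound 3 (0.49 log units; beyond the scatter). For compound 3 the estimate is 40000 nM, with an expected range from 8000 nM to 180000 nM.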

Compound 3, solubility: 180000 nM
Estimate against measurement, compound 3: 4.5-fold (0.65 log units) below; measured number inside the range.
By their numbers in this assay, from the lowest: compound 1; then compounds 2 and 3 (each within the scatter of the next).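

In this assay, the step on the carbonyl carbon reads a 1.4-fold higher number from compound 2 to compound 3 (0.16 log units; within the scatter), so the group with two four-membered non-aromatic rings cannot be told apart here from the open-chain (2-(dimethylamino)ethyl)(methyl)amino. Against the 4-methylpiperazin-1-yl group, the same ringed group gives a 230-fold higher number from compound 1 to compound 3 (2.35 log units; beyond the scatter), a large step, so the presence of rings on this carbonyl carbon does not by itself go with the low number of compound 1, and compound 1 now stands apart from two different groups, one with rings and one without. Nothing available gives a cause for this difference between compound 1 and the other two compounds.

The compounds shown leave open whether the low number belongs to 4-methylpiperazin-1-yl in particular or to six-membered rings on this carbon more widely, which a morpholin-4-yl or a 4-(dimethylamino)piperidin-1-yl group would test. Also open, as far as these compounds go, is whether the ringed group needs both four-membered rings, which a 3-(dimethylamino)azetidin-1-yl group, with a single such ring, would test in this assay.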